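Changing the Aryl Group on Compound 3

This account rests on a few compounds, and the source may have more. Where it says the series, first, only, none or still open, it means among the compounds named here.

The three measured compounds share one core and differ in the group carried by the amide nitrogen. In a functional assay on HepG2 cells (Homo sapiens) for inhibition, read by MTT assay, with a stated time of 72 h (on this read-out lower numbers stand for stronger inhibition and higher numbers for weaker inhibition), compound 1 `CC(C)n1ncc2c(C(=O)Nc3ccccc3)cccc21` gives 23700 nM. Compound 2 `CC(C)n1ncc2c(C(=O)NC3CCCC3)cccc21` reaches only a limit in this assay, > 40000 nM. Among the measured compounds shown here, the one step between compounds that differ in a single place is an at least 1.6-fold higher number from compound 1 to compound 2 (0.22 log units; that floor lies within the scatter), and its size cannot be pinned down. Compound 3 `CC(C)n1ncc2c(C(=O)NCc3cn(-c4cccc(F)c4)nn3)cccc21` also sits at a limit in this assay, > 40000 nM. That ceiling is the limit of > 40000 nM in this assay, at which 2 of the 3 values shown sit. Compound 3 therefore stands at the weak edge of what the numbers shown can tell: no finite inhibitory concentration has been recorded for it.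

Compound 4 `CCc1ccc(-n2cc(CNC(=O)c3cccc4c3cnn4C(C)C)nn2)cc1` differs from compound 3 in one place: 4-ethylphenyl in place of 3-fluorophenyl on an aromatic nitrogen. For the measured compounds named here, none of the measured steps touches this place; the only measured step concerns the amide nitrogen, and it stays within the scatter. Nothing measured points to a gain or a loss beyond the scatter, so the expectation for compound 4 is to remain near the limit, with the expected step being a step that the limit leaves unreadable from compound 3 to compound 4. Compound 4 is estimated at 45000 nM, with a range from 15000 nM to 130000 nM.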

Compound 4, half-maximal inhibitory concentration: > 40000 nM
Compound 4 gave a limit, no number; the forecaster's own chance of this, stated with the estimate: 70%; the middle value is on the limit's open side.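

In this assay compound 4 gives only a limit, > 40000 nM. Compound 3 gives a limit as well, so no step can be read between compound 3 and compound 4. Left open is how 3-fluorophenyl and 4-ethylphenyl on the aromatic nitrogen compare, and the values shown offer only one shared ceiling: the limit of > 40000 nM in this assay, at which 3 of the 4 values shown sit.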